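Working notes: 3-acetylphenyl in place of 3,5-dimethoxyphenyl

A few compounds are considered here, and "the series" means these few. Any claim that something is new, unique, unknown or untested is made for them only; others in the source may bear on it.

The three measured compounds share one core and differ in a single aromatic substituent. In a functional assay on SK-OV-3 cells (Homo sapiens) for antiproliferative activity, read by MTT assay, with a stated time of 72 h (a lower number here means a stronger inhibitor, a higher number a weaker inhibitor), compound 1 (`O=C(CCc1cccc2c1B(O)OC2)Nc1cccc(I)c1`), the iodo member, gives 630 nM. Compound 2 (`O=C(CCc1cccc2c1B(O)OC2)Nc1cccc(-c2ccc(Cl)cc2)c1`), with 4-chlorophenyl, gives 220 nM. Compound 3 (`COc1cc(OC)cc(-c2cccc(NC(=O)CCc3cccc4c3B(O)OC4)c2)c1`), with 3,5-dimethoxyphenyl, gives 44 nM, the lowest number of the three, and its steps to both others lie beyond the scatter.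

Compound 4 (`CC(=O)c1cccc(-c2cccc(NC(=O)CCc3cccc4c3B(O)OC4)c2)c1`) has not been measured. It carries 3-acetylphenyl in place of 3,5-dimethoxyphenyl on an aromatic carbon.

Among the measured compounds shown here, three measured steps bear on this change. Replacing iodo gave a 2.9-fold lower number from compound 1 to compound 2 (0.46 log units; beyond the scatter), a modest step, and a 14-fold lower number from compound 1 to compound 3 (1.16 log units; beyond the scatter), a large one. For the measured compounds named here, the closest precedent is the exchange of one aryl group for another, which gave a 5.0-fold lower number from compound 2 to compound 3 (0.70 log units; beyond the scatter), also modest. Going by the values given here, no measured compound carries an acetyl group, and two aryl groups are too few to support a rule. Among the compounds with values here, compound 3 holds the lowest number so far at 44 nM, so a modest move toward a higher number in this assay is the expectation. For compound 4 the expected step is a 2.3-fold higher number from compound 3 to compound 4 (0.36 log units; beyond the scatter). For compound 4 the estimated value is 100 nM, with an expected range of 35 nM to 300 nM.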

Compound 4, half-maximal inhibitory concentration: 68 nM
Beside the measured number, compound 4's estimate is 1.5-fold (0.17 log units) above it; the measured number falls inside the stated range.
By their numbers in this assay, from the lowest: compounds 3 and 4 (each within the scatter of the next); then compound 2; then compound 1.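

Notes on the position: in this assay the exchange gives a 1.5-fold higher number from compound 3 to compound 4 (0.19 log units; within the scatter), so at this place, on an aromatic carbon meta to a large group, 3-acetylphenyl and 3,5-dimethoxyphenyl cannot be told apart, and the low number of compound 3 no longer rests on one aryl group alone. Set against the other two groups, 3-acetylphenyl gives a 3.2-fold lower number from compound 2 to compound 4 (0.51 log units; beyond the scatter) and also a 9.3-fold lower number from compound 1 to compound 4 (0.97 log units; beyond the scatter), so a second oxygen-bearing aryl group stands clear of both 4-chlorophenyl and iodo. Among these four compounds, then, the two aryl groups carrying oxygen share the low end of the series, while compound 2 shows that an aryl group without oxygen does not reach it, and the change from two hydrogen-bond acceptors to one leaves no step beyond the scatter.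

No measurement at hand accounts for this result. Open, going by these compounds, is whether unsubstituted phenyl, a single methoxy group, an amine or a carboxylic acid on the same ring would stay with compound 3 and compound 4 or fall back toward compound 2.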